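This account rests on a few compounds, and the source may have more. Where it says the series, first, only, none or still open, it means among the compounds named here.

Compound 2 `CNc1ncnc2c1c(-c1cccs1)cn2[C@@H]1O[C@H](CO)[C@@H](O)[C@H]1O` sits at the edge of what the measurement can see. In an ADME assay on BJ cells (Homo sapiens), read by MTT assay, with a stated time of 72 h (a higher number here means a weaker inhibitor, a lower number a stronger inhibitor), compound 2 gives only the limit of the assay, > 100000 nM. Compound 1 `CNc1ncnc2c1c(I)cn2[C@@H]1O[C@H](CO)[C@@H](O)[C@H]1O` likewise gives the limit > 100000 nM in this assay. Compound 3 `CN(C)c1ncnc2c1c(-c1cccs1)cn2[C@@H]1O[C@H](CO)[C@@H](O)[C@H]1O` also stops at the limit, > 100000 nM, in this assay. Because the limit of > 100000 nM in this assay, at which 3 of the 3 values shown sit, is all that the three values show, the steps a step that the two limits leave unreadable from compound 1 to compound 2 and a step that the two limits leave unreadable from compound 2 to compound 3 cannot be sized, so neither gives readable guidance for the change ahead. Compound 4 `CNc1ncnc2c1c(-c1ccco1)cn2[C@@H]1O[C@H](CO)[C@@H](O)[C@H]1O` differs from compound 2 by furan-2-yl in place of thiophen-2-yl on an aromatic carbon. With every measured value a limit, no step beyond the scatter can be foreseen. The step from compound 2 to compound 4 is estimated as a number no higher from compound 2 to compound 4 (the limit leaves the size open). Compound 4 is therefore expected to remain at the limit, estimated at 100000 nM, between 30000 nM and 300000 nM.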

Compound 4, half-maximal inhibitory concentration: 5040 nM
For compound 4 the middle estimate is 20-fold (1.30 log units) above the measured one; measured number below the stated range.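

Swapping sulfur for oxygen within the five-membered aromatic ring at this aromatic carbon is enough to bring activity into view: furan-2-yl in place of thiophen-2-yl gives an at least 19-fold lower number from compound 2 to compound 4 (1.29 log units; beyond the scatter). Furan-2-yl in place of iodo gives an at least 19-fold lower number from compound 1 to compound 4 (1.29 log units; beyond the scatter). The earlier steps cannot be read, and compound 4 is the first compound here to leave the limit: the limit of > 100000 nM in this assay, at which 3 of the 4 values shown sit.

From the compounds shown here alone, whether the second methyl on the nitrogen in compound 3 would keep this value with furan-2-yl stays open. So does how a phenyl ring or an amine at this aromatic carbon would read.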